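Swapping methoxy for fluoro on the anilide of compound 3

The source may hold more compounds than are shown below. What is called first, only, known or untested is meant among the compounds shown, and "the series" means these compounds.

Measured compounds:
Compound 1, `COc1ccc2c(=O)c(/C=C/C(=O)NCc3ccc(F)cc3)coc2c1`, gives 133000 nM in an ADME assay on HepG2 2.2.15 cells (Homo sapiens) for cytotoxicity, read by MTT assay, with stated times of 48 h and 9 days; on this read-out lower numbers stand for higher toxicity in this test and higher numbers for lower toxicity in this test.
Compound 2, `COc1ccc2c(=O)c(/C=C/C(=O)NCc3ccccc3F)coc2c1`, gives 146000 nM in this assay.
Compound 3, `COc1ccc(NC(=O)/C=C/c2coc3cc(OC)ccc3c2=O)cc1`, gives 718000 nM in this assay.

Compound 3 stands highest of the three numbers, that is, it is the least toxic of the three in this assay. The steps to it are a 5.4-fold higher number from compound 1 to compound 3 (0.73 log units; beyond the scatter) and a 4.9-fold higher number from compound 2 to compound 3 (0.69 log units; beyond the scatter), both beyond the scatter. Between compounds 1 and 2 there is only a 1.1-fold higher number from compound 1 to compound 2 (0.04 log units; within the scatter), so moving the fluoro around the benzyl ring changed nothing that can be told apart from noise.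

Compound 4, `COc1ccc2c(=O)c(/C=C/C(=O)Nc3ccc(F)cc3)coc2c1`, differs from compound 3 by fluoro in place of methoxy on an aromatic carbon. Going by the values given here, no measured step isolates this swap: the two steps that reach compound 3 exchange a fluorobenzyl for a methoxyphenyl, so they change the chain and the substituent at once and bear on compound 4 only loosely. Since compound 4 keeps the phenyl directly on the amide nitrogen, the expectation is a number close to compound 3, perhaps somewhat lower, within a 1.4-fold lower number from compound 3 to compound 4 (0.16 log units; within the scatter). Compound 4 is therefore estimated at 500000 nM, in the range 200000 nM to 1000000 nM.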

Compound 4, half-maximal cytotoxic concentration: 743000 nM
Beside the measured number, compound 4's estimate is 1.5-fold (0.17 log units) below it; measured number inside the range.
By their numbers in this assay, from the lowest: compounds 1 and 2 (each within the scatter of the next); then compounds 3 and 4 (each within the scatter of the next).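

In this assay, going by these compounds alone, compound 4 gives the first direct reading of a single swap on the aromatic carbon para to a large group: with fluoro in place of methoxy, there is a 1.0-fold higher number from compound 3 to compound 4 (0.01 log units; within the scatter), so this assay cannot tell the two groups apart at this position. The result also shows that methoxy is not needed for the gap from the benzyl amides, since with a fluoro on the ring in all three compounds there is a 5.1-fold higher number from compound 2 to compound 4 (0.71 log units; beyond the scatter) and a 5.6-fold higher number from compound 1 to compound 4 (0.75 log units; beyond the scatter); across these four compounds, the two with the ring directly on the amide nitrogen give the higher numbers, and none goes against this. Nothing available here accounts for either the match or the gap.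

Two groups as different as methoxy and fluoro matching here does not settle whether any group at this position would do, and an amine or a carboxylic acid there could still give a different number. The compounds shown also leave open how a longer chain, such as a two-carbon link between the amide nitrogen and the ring, would compare with the benzyl and phenyl amides.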